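This account rests on a few compounds, and the source may have more. Where it says the series, first, only, none or still open, it means among the compounds named here.

Compound 3 `Cc1cc(=O)n(-c2cccc(F)c2)nc1C(=O)Nc1ccc(Oc2ncnc3[nH]ccc23)c(F)c1` sits at the upper end of the numbers obtained so far in a functional assay on MCF7 cells (Homo sapiens) for cytotoxicity, read by MTT assay, with a stated time of 72 h (on this read-out higher numbers stand for weaker inhibition and lower numbers for stronger inhibition), at 32000 nM. Its nearest neighbour is compound 2 `Cc1cc(=O)n(-c2cccc(F)c2)nc1C(=O)Nc1ccc(Oc2ncnc3[nH]ccc23)cc1`, which in this assay gives 9670 nM; the two differ by a 3.3-fold higher number from compound 2 to compound 3 (0.52 log units; beyond the scatter). Compound 1 `Cn1ccc2c(Oc3ccc(NC(=O)c4nn(-c5ccc(Cl)cc5)ccc4=O)cc3)ccnc21` is reported in this assay only as a limit, > 60000 nM, and so supplies no number for comparison (the limit of > 60000 nM in this assay, at which 1 of the 3 values shown sits).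

Compound 4 `Cc1cc(=O)n(-c2ccc(Br)cc2F)nc1C(=O)Nc1ccc(Oc2ncnc3[nH]ccc23)c(F)c1` is reached from compound 3 by 4-bromo-2-fluorophenyl in place of 3-fluorophenyl on an aromatic nitrogen. For the measured compounds named here, the only measured step in this set, a 3.3-fold higher number from compound 2 to compound 3 (0.52 log units; beyond the scatter), concerns a fluoro added to a different ring and thus does not speak directly to a change on the aromatic nitrogen; no measured pair varies that aryl group. With nothing to indicate a direction, the expected step is one that stays within or close to the scatter. Compound 4 is therefore estimated at 30000 nM in this assay, with a range from 10000 nM to 90000 nM, corresponding to an expected 1.1-fold lower number from compound 3 to compound 4 (0.03 log units; within the scatter).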

Compound 4, half-maximal inhibitory concentration: 26600 nM
For compound 4 the middle estimate is 1.1-fold (0.05 log units) above the measured one; the measured number falls inside the stated range.
By their numbers in this assay, from the lowest: compound 2; then compounds 4 and 3 (each within the scatter of the next). At a limit, above all of these: compound 1.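

For the compounds shown here, this is the first measured change to the aryl group on the aromatic nitrogen: in this assay, 4-bromo-2-fluorophenyl in place of 3-fluorophenyl gives a 1.2-fold lower number from compound 3 to compound 4 (0.08 log units; within the scatter). With compound 3 as the background, this exchange of halogenated phenyl groups therefore leaves the number within the scatter, whereas the earlier fluoro change on the other aromatic ring gave a 3.3-fold higher number from compound 2 to compound 3 (0.52 log units; beyond the scatter). Nothing in the data shown gives a reason for either result.

As far as these compounds go, it remains open whether 4-bromo-2-fluorophenyl would give the same outcome without the added fluoro, on the background of compound 2. Also open, from the compounds shown here alone, is whether a phenyl ring bearing an amine, a carboxylic acid or a methoxy group at this position would shift the number beyond the scatter.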